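Thiophen-3-yl to Phenyl: Estimating Compound 4

The source may hold more compounds than are shown below. What is called first, only, known or untested is meant among the compounds shown, and "the series" means these compounds.

Compound 1 `COc1ncnc2c1c(-c1ccsc1)cn2[C@@H]1O[C@H](CO)[C@@H](O)[C@H]1O`: 2570 nM
Compound 2 `CN(C)c1ncnc2c1c(-c1ccsc1)cn2[C@@H]1O[C@H](CO)[C@@H](O)[C@H]1O`: 3480 nM
Compound 3 `COc1nc(N)nc2c1c(-c1ccsc1)cn2[C@@H]1O[C@H](CO)[C@@H](O)[C@H]1O`: > 20000 nM

In a functional assay on CCRF-CEM cells (Homo sapiens), read by MTT assay, with a stated time of 72 h (on this read-out higher numbers stand for weaker inhibition and lower numbers for stronger inhibition), compound 1 gives 2570 nM, the lowest of the two numbers shown. Compound 2 gives 3480 nM, and a 1.4-fold higher number from compound 1 to compound 2 (0.13 log units; within the scatter). For compound 3 the value is a limit, (the limit of > 20000 nM in this assay, at which 1 of the 3 values shown sits), so no number is known for it; still, an at least 7.7-fold higher number from compound 1 to compound 3 (0.89 log units; beyond the scatter). Compound 4 `COc1ncnc2c1c(-c1ccccc1)cn2[C@@H]1O[C@H](CO)[C@@H](O)[C@H]1O` differs from compound 1 at another place: phenyl in place of thiophen-3-yl on an aromatic carbon. Neither measured step touches that ring, so they give no direct guide to this change. With nothing pointing to a large shift in this assay, compound 4 is expected to stay near compound 1, at an estimated 3000 nM (range 1000 nM to 10000 nM), meaning an expected step of a 1.2-fold higher number from compound 1 to compound 4 (0.07 log units; within the scatter).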

Compound 4, half-maximal inhibitory concentration: > 20000 nM
Compound 4 was reported as a limit; the forecaster's own chance of this, stated with the estimate: 10%; middle value at least 6.6-fold (0.82 log units) from the limit.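

Within the data shown here, exchanging thiophen-3-yl for phenyl at this position is not a neutral swap: in this assay it gives an at least 7.7-fold higher number from compound 1 to compound 4 (0.89 log units; beyond the scatter) and so shows that the ring on this aromatic carbon matters, which the earlier steps, made at other places, could not show. As far as these compounds go, the value of compound 4 is a limit, not a number, so the full size of this step stays unknown: the limit of > 20000 nM in this assay, at which 2 of the 4 values shown sit.

From the compounds shown here alone, only thiophen-3-yl and phenyl appear at this place, so it stays open whether furan-3-yl, pyridin-3-yl or a small methyl would keep the activity of compound 1.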